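Chloro in place of methyl: one step still unmeasured

The source may report more compounds than this note shows. Statements on the series, on what has been measured and on what is new or still open speak of the compounds shown alone.

Compound 1 (`Cc1cn2c(/C=N/NC(=N)N)c(-c3ccncc3)nc2s1`) gives 15800 nM in a functional assay on colon cells (Homo sapiens) for antiproliferative activity (on this read-out lower numbers stand for stronger inhibition of growth and higher numbers for weaker inhibition of growth), and compound 2 (`Cc1sc2nc(-c3ccccn3)c(/C=N/NC(=N)N)n2c1C`) gives 18200 nM on the same read-out. Within the data shown here, these two values lie within the scatter of each other, so compound 1 stands level with the only other number available. Among the measured compounds shown here, no measured pair yet differs in just one place, so no direct precedent exists for the next comparison. Compound 3 (`N=C(N)N/N=C/c1c(-c2ccncc2)nc2sc(Cl)cn12`) awaits measurement and departs from compound 1 by chloro in place of methyl on an aromatic carbon with chloro in place of methyl on an aromatic carbon, next to the ring sulfur. For the measured compounds named here, with no measured step to lean on, no change beyond the scatter is expected in this assay and the estimated step is a 1.3-fold lower number from compound 1 to compound 3 (0.12 log units; within the scatter) on the side of slightly stronger inhibition of growth. Compound 3 is expected to read 12000 nM within a range from 4000 nM to 35000 nM when it is measured.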

Compound 3, concentration for 50% growth inhibition: 8130 nM
The estimate for compound 3 lay 1.5-fold (0.17 log units) above the measured number; measured number inside the range.
By their numbers in this assay, from the lowest: compounds 3, 1 and 2 (each within the scatter of the next, the first and the last beyond it).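

Among these compounds, this is the first measured comparison that differs in one place, and in this assay chloro in place of methyl on this aromatic carbon, next to the ring sulfur, gives a 1.9-fold lower number from compound 1 to compound 3 (0.29 log units; within the scatter) and so leaves the read-out level. The position therefore accepts chloro for methyl, one heavy atom for one heavy atom, with no change in growth inhibition that can be told apart from the scatter. No measurement at hand offers an explanation for this outcome.

The compounds shown leave open how an amine, a carboxylic acid or a longer chain on this same aromatic carbon would read in this assay and so how far this tolerance extends. They also leave open whether chloro in place of methyl would give a similar step on the core of compound 2.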